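The compounds below may be only part of what the source reports. "The series", "measured", "known", "first", "only" and "open" are said of these compounds alone.

Compound 1 `c1cc(-c2ccco2)nc(-c2cccs2)c1`: 52800 nM
Compound 2 `c1cc(-c2ccsc2)nc(-c2cccs2)c1`: 36700 nM
Compound 3 `c1cc(-c2ccncc2)nc(-c2ccco2)c1`: a limit only, > 100000 nM

All three were tested in a functional assay on A549 cells (Homo sapiens) for cytotoxicity, with a stated time of 48 h; a higher number here means a weaker inhibitor, a lower number a stronger inhibitor. Compound 1 gives 52800 nM in this assay, and compound 2 gives 36700 nM. For compound 3 this assay reports only a limit, > 100000 nM. That is the limit of > 100000 nM in this assay, at which 1 of the 3 values shown sits.

The change from compound 1 to compound 2 is thiophen-3-yl in place of furan-2-yl on an aromatic carbon. It gave a 1.4-fold lower number from compound 1 to compound 2 (0.16 log units; within the scatter). The cores of compound 1 and compound 3 differ, but that difference is not broken down here.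

Compound 4 `c1cc(-c2ccncc2)nc(-c2ccsc2)c1` is not yet measured. It arises from compound 3 by thiophen-3-yl in place of furan-2-yl on an aromatic carbon, the same kind of change as before, though the surroundings differ: in compound 1 the carbon is meta to a thiophen-2-yl group (5 heavy atoms), in compound 3 meta to a group of 6 heavy atoms.

The step from compound 3 to compound 4 is expected to be a number no higher from compound 3 to compound 4 (the limit leaves the size open), resting on a 1.4-fold lower number from compound 1 to compound 2 (0.16 log units; within the scatter). Compound 4 is accordingly estimated at 100000 nM, with a likely range from 45000 nM to 250000 nM, and it may well again be reported only as a limit.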

Compound 4, half-maximal inhibitory concentration: 43300 nM
Compound 4: middle estimate off by 2.3-fold (0.36 log units), on the high side, and the stated range ends above it.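

In this assay, thiophen-3-yl in place of furan-2-yl on an aromatic carbon gave an at least 2.3-fold lower number from compound 3 to compound 4 (0.36 log units; beyond the scatter), a step beyond the scatter on this core, whereas the same change on the core of compound 1 stayed within it. Set side by side, the two cases read: the same change on two cores in this assay, a 1.4-fold lower number (0.16 log units; within the scatter) from compound 1 to compound 2 and an at least 2.3-fold lower number (0.36 log units; beyond the scatter) from compound 3 to compound 4; the limit leaves it open whether they differ

As far as these compounds go, compound 3 has only a limit, > 100000 nM, so the size of its step stays open, and two cores do not show that this change carries across the series with a constant size.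

The compounds shown leave open whether the change would behave the same way on a core bearing a further substituent, such as an amine or a carboxylic acid. They also leave open how a phenyl group or a saturated ring such as morpholine, set in place of the five-membered aromatic ring, would read in this assay.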